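Exchange of a group on the chain carbon

The source may report more compounds than this note shows. Statements on the series, on what has been measured and on what is new or still open speak of the compounds shown alone.

In a functional assay on COR-L23 cells (Homo sapiens) for antiproliferative activity, read by CellTiter-Glo, with a stated time of 72 h (on this read-out lower numbers stand for stronger inhibition and higher numbers for weaker inhibition), compound 3 (`C[C@@H](c1ccc(NC(=O)N2CC(c3cccnc3)C2)cc1)N1Cc2ccccc2C1=O`) gives 8 nM and compound 1 (`O=C(Nc1ccc(CN2Cc3ccccc3C2=O)cc1)N1CC(c2cccnc2)C1`) gives 9.9 nM, two values within the scatter of each other. Compound 2 (`O=C(Nc1ccc(CN2Cc3ccccc3C2=O)cc1)N1CCC(c2cccnc2)CC1`) gives 1150 nM, beyond the scatter from compound 3, on the side of weaker inhibition.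

Compound 4 (`C[C@H](NC(=O)[C@@H]1CCCN1C)c1ccc(NC(=O)N2CC(c3cccnc3)C2)cc1`) differs from compound 3 as follows: a group of 9 heavy atoms (6 carbon, 2 nitrogen, 1 oxygen; one five-membered non-aromatic ring with 1 hetero atom) in place of a group of 10 heavy atoms (8 carbon, 1 nitrogen, 1 oxygen; one five-membered non-aromatic ring with 1 hetero atom, one six-membered aromatic ring of carbon only), on a saturated chain carbon bound to an aromatic carbon and a saturated chain carbon. The entering ((1-methylpyrrolidin-2-yl)carbonyl)amino group sits on a saturated chain carbon bound to an aromatic carbon and a saturated chain carbon.

Among the measured compounds shown here, only one measured step touches this part of the series: a 1.2-fold lower number from compound 1 to compound 3 (0.09 log units; within the scatter). That step is a methyl in place of hydrogen on the chain carbon, with the group of compound 3 still attached, so it shows nothing about exchanging that group. For the measured compounds named here, no measured compound carries the entering group. Compound 2 at 1150 nM shows that a single structural difference in this small set can move the number far, so the range has to stay wide.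

A moderate move towards weaker inhibition is expected, with the estimated step being a 5.0-fold higher number from compound 3 to compound 4 (0.70 log units; beyond the scatter). In this assay the estimate for compound 4 is 40 nM, with an expected range of 6 nM to 300 nM.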

Compound 4, half-maximal inhibitory concentration: 38 nM
For compound 4 the middle estimate is 1.1-fold (0.02 log units) above the measured one; low and high end bracket the measured number.
By their numbers in this assay, from the lowest: compounds 3 and 1 (each within the scatter of the next); then compound 4; then compound 2.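

In this assay, the step of a 4.8-fold higher number from compound 3 to compound 4 (0.68 log units; beyond the scatter) is a modest loss, so the saturated chain carbon bound to an aromatic carbon and a saturated chain carbon accepts the ((1-methylpyrrolidin-2-yl)carbonyl)amino group in place of the group carrying the six-membered aromatic ring, at a measurable cost. Among the compounds shown here, the only earlier step at this carbon, a 1.2-fold lower number from compound 1 to compound 3 (0.09 log units; within the scatter), exchanged hydrogen for methyl and kept the attached group, so the new step is the only one that reads the group itself. The exchange removes the six-membered aromatic ring and adds a hydrogen-bond donor in a single step, and nothing measured here separates these two differences or accounts for the change in the number.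

The compounds shown leave open how a plain amine, an acetylamino group or a carboxylic acid on this carbon would read, and so whether the five-membered ring of the entering group contributes at all. They also leave open what the opposite configuration at the defined stereocentre of the entering group would do, and whether hydrogen in place of the methyl on the chain carbon would still leave the number unchanged with this group attached.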